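A few compounds are considered here, and "the series" means these few. Any claim that something is new, unique, unknown or untested is made for them only; others in the source may bear on it.

In a functional assay on MCF7 cells (Homo sapiens) for inhibition, with a stated time of 96 h (on this read-out lower numbers stand for stronger inhibition and higher numbers for weaker inhibition), compound 1 (`COc1cc(C(=O)c2cn(-c3ccc(C)cc3)cc2-c2ccsc2)cc(OC)c1OC`) gives 4 nM, while compound 2 (`COc1cc(C(=O)c2cn(-c3cccc(C)c3)cc2-c2ccncc2)cc(OC)c1OC`) gives 65 nM, the higher of the two numbers and so the weaker inhibition, by a gap beyond the usual scatter. Going from compound 2 to compound 3 (`COc1cc(C(=O)c2cn(-c3ccc(C)cc3)cc2-c2ccncc2)cc(OC)c1OC`), 4-methylphenyl takes the place of 3-methylphenyl on an aromatic nitrogen: 4-methylphenyl in place of 3-methylphenyl on an aromatic nitrogen. For the measured compounds named here, no measured pair shows this swap alone. Compound 1, which also carries 4-methylphenyl, gives 4 nM, so a small fall in the number is expected, near the edge of the scatter. The estimated step is a 2.2-fold lower number from compound 2 to compound 3 (0.34 log units; beyond the scatter). For compound 3 the expected value is 30 nM, with an estimated range of 8 nM to 110 nM.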

Compound 3, half-maximal inhibitory concentration: 9 nM
The estimate for compound 3 lay 3.3-fold (0.52 log units) above the measured number, within the range that was stated.
By their numbers in this assay, from the lowest: compound 1; then compound 3; then compound 2.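

Moving the methyl group on the phenyl ring, so that 4-methylphenyl replaces 3-methylphenyl on the aromatic nitrogen, gives a 7.2-fold lower number from compound 2 to compound 3 (0.86 log units; beyond the scatter) in this assay, showing that the methyl's place alone changes the result. With 4-methylphenyl kept, pyridin-4-yl in place of thiophen-3-yl on an aromatic carbon gives a 2.3-fold higher number from compound 1 to compound 3 (0.35 log units; beyond the scatter). The data shown offer no explanation for either step. From the compounds shown here alone, it remains open whether 4-ethylphenyl or 4-methoxyphenyl on the aromatic nitrogen would fit the same trend, and whether the methyl shift acts alike with thiophen-3-yl.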